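The source may hold more compounds than are shown below. What is called first, only, known or untested is meant among the compounds shown, and "the series" means these compounds.

Of the compounds shown here, three have been measured. Compound 1, `Cc1nc(C2CC2)cc2nn(-c3ccccc3)cc12`, gives 25900 nM in a functional assay on K562 cells (Homo sapiens) for inhibition, read by fluorescence, with a stated time of 72 h; a higher number here means a weaker inhibitor of growth, a lower number a stronger inhibitor of growth. Compound 2, `Cc1nc(-c2ccsc2)cc2nn(-c3ccccc3)cc12`, gives 10000 nM in this assay. Compound 3, `c1ccc(-n2cc3cnc(C4CC4)cc3n2)cc1`, gives 60500 nM in this assay.

Compound 3 stands at the highest number of the three. Its core differs from that of compound 1 by hydrogen in place of methyl on an aromatic carbon, and this change is a step of a 2.3-fold higher number from compound 1 to compound 3 (0.37 log units; beyond the scatter). Within the core of compound 1, the change thiophen-3-yl in place of cyclopropyl on an aromatic carbon gives a step of a 2.6-fold lower number from compound 1 to compound 2 (0.41 log units; beyond the scatter), so compound 2 sits at the lowest number of the three.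

Compound 4, `c1ccc(-n2cc3cnc(-c4ccsc4)cc3n2)cc1`, has not yet been measured. It differs from compound 3 by thiophen-3-yl in place of cyclopropyl on an aromatic carbon. For the measured compounds named here, this is the same kind of change as the one from compound 1 to compound 2, made on the core of compound 3 rather than that of compound 1; the surroundings of the place differ only in that the place in compound 1 is also meta to a methyl group, which compound 3 lacks. Whether this change behaves alike on both cores rests on a single measured pair, so the expectation is uncertain. Compound 4 is expected to show a step of a 2.5-fold lower number from compound 3 to compound 4 (0.40 log units; beyond the scatter), about the size of the step from compound 1 to compound 2. Compound 4 is therefore estimated to give 24000 nM in this assay, within a range from 10000 nM to 60000 nM.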

Compound 4, concentration for 50% growth inhibition: 8300 nM
The estimate for compound 4 lay 2.9-fold (0.46 log units) above the measured number, and the stated range ends above it.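

Carried onto the core of compound 3, thiophen-3-yl in place of cyclopropyl gives a 7.3-fold lower number from compound 3 to compound 4 (0.86 log units; beyond the scatter) in this assay, so the change lowers the number on both cores, but its size does not carry over: the same change on two cores in this assay, a 2.6-fold lower number (0.41 log units; beyond the scatter) from compound 1 to compound 2 and a 7.3-fold lower number (0.86 log units; beyond the scatter) from compound 3 to compound 4, 2.8-fold (0.45 log units) apart, beyond the scatter of two such steps. The same four compounds can also be read through the other change, where hydrogen in place of methyl gives a 1.2-fold lower number from compound 2 to compound 4 (0.08 log units; within the scatter) with thiophen-3-yl present, unlike the step seen with cyclopropyl present: the same change on two cores in this assay, a 2.3-fold higher number (0.37 log units; beyond the scatter) from compound 1 to compound 3 and a 1.2-fold lower number (0.08 log units; within the scatter) from compound 2 to compound 4, 2.8-fold (0.45 log units) apart, beyond the scatter of two such steps. Together these readings show that, among these four compounds, the effect of each change depends on what stands at the other place, but both comparisons rest on one set of four compounds, so they do not show why this is so or whether it holds for any other pair of groups.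

The compounds shown leave open whether another group on the aromatic carbon next to the ring nitrogen, such as an amine, a furan-3-yl ring or a longer alkyl chain, would keep the direction seen with thiophen-3-yl. They also leave open whether an ethyl group in place of methyl, or a change to the phenyl ring, would alter how far a step carries from one core to another.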